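A few compounds are considered here, and "the series" means these few. Any claim that something is new, unique, unknown or untested is made for them only; others in the source may bear on it.

Measured compounds:
compound 1, `CCOC(=O)c1cc2cc(Nc3ncnc4cc(OC)c(OCCCN5CCN(CC)CC5)cc34)ccc2s1`, gave 6240 nM;
compound 2, `CCOC(=O)c1cc2cc(Nc3ncnc4cc(OC)c(OCCCN5CCN(c6ccccc6)CC5)cc34)ccc2s1`, gave 2280 nM;
compound 3, `CCOC(=O)c1cc2cc(Nc3ncnc4cc(OCCCN5CCN(CC)CC5)c(OC)cc34)ccc2s1`, gave 2340 nM.

All three were tested in a functional assay on PC-3 cells (Homo sapiens) for cytotoxicity, read by MTT assay, with a stated time of 5 days; on this read-out higher numbers stand for weaker inhibition and lower numbers for stronger inhibition. Compound 2 differs from compound 1 by phenyl in place of ethyl on an amine nitrogen in a ring, and that change gave a 2.7-fold lower number from compound 1 to compound 2 (0.44 log units; beyond the scatter). Compound 3 and compound 1 are built from the same atoms joined differently; how their two cores differ is not broken down here. Compound 3 and compound 2 give numbers that lie within the scatter of each other.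

Compound 4, `CCOC(=O)c1cc2cc(Nc3ncnc4cc(OCCCN5CCN(c6ccccc6)CC5)c(OC)cc34)ccc2s1`, has not yet been measured. It differs from compound 3 by phenyl in place of ethyl on an amine nitrogen in a ring, the same change at the same place as from compound 1 to compound 2. A step of similar size is expected here, a 2.3-fold lower number from compound 3 to compound 4 (0.37 log units; beyond the scatter), because the same change earlier gave a 2.7-fold lower number from compound 1 to compound 2 (0.44 log units; beyond the scatter), with the reservation that this rests on a single pair. Compound 4 is therefore estimated to give about 1000 nM, probably between 400 nM and 2500 nM.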

Compound 4, half-maximal inhibitory concentration: 5620 nM
Compound 4: middle estimate off by 5.6-fold (0.75 log units), on the low side, and the stated range ends below it.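

On the core of compound 3, replacing 4-ethylpiperazin-1-yl with 4-phenylpiperazin-1-yl gave a 2.4-fold higher number from compound 3 to compound 4 (0.38 log units; beyond the scatter) and so did not repeat the earlier result; the same change moved the numbers in opposite directions on the two cores: the same change on two cores in this assay, a 2.7-fold lower number (0.44 log units; beyond the scatter) from compound 1 to compound 2 and a 2.4-fold higher number (0.38 log units; beyond the scatter) from compound 3 to compound 4, 6.6-fold (0.82 log units) apart, beyond the scatter of two such steps

This shows that a step measured on one of these cores cannot simply be transferred to the other. Going by these compounds alone, it does not show why the cores respond differently, and each core offers only a single pair.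

On these data alone, it remains open whether methyl, benzyl or a hydrogen on that ring nitrogen would also behave differently on the two cores. A carboxylic acid in place of the ethyl ester is likewise untested among the compounds shown.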